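This account rests on a few compounds, and the source may have more. Where it says the series, first, only, none or still open, it means among the compounds named here.

Measured compounds:
Compound 1, `CCN(CC)c1ccc(-c2ccc(C(=O)OC)cc2)nn1`, gives 90 nM.
Compound 2, `CCOC(=O)c1ccc(-c2ccc(N(CC)CC)nn2)cc1`, gives 1500 nM.
Compound 3, `CCOC(=O)c1ccc(-c2ccc(OCC)nn2)cc1`, gives only a limit of the assay, > 25000 nM.

All three were tested in a functional assay on NCI-H727 cells (Homo sapiens) for antiproliferative activity, with a stated time of 48 h; a higher number here means a weaker inhibitor, a lower number a stronger inhibitor. Compound 2 differs from compound 1 by methyl in place of hydrogen on a saturated chain carbon bound to an oxygen next to a carbonyl group, and in this assay the step is a 17-fold higher number from compound 1 to compound 2 (1.22 log units; beyond the scatter). Compound 3 differs from compound 2 by ethoxy in place of diethylamino on an aromatic carbon, with the step of an at least 16-fold higher number from compound 2 to compound 3 (1.22 log units; beyond the scatter); compound 3 sits at the limit of the assay (the limit of > 25000 nM in this assay, at which 1 of the 3 values shown sits). Between compound 1 and compound 3 the difference between the two cores is not broken down here.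

Compound 4, `CCOC(=O)c1ccc(-c2ccc(OC(C)C)nn2)cc1`, has not yet been measured. It differs from compound 3 by methyl in place of hydrogen on a saturated chain carbon bound to an oxygen on an aromatic ring and a saturated chain carbon. This is the same kind of change as that from compound 1 to compound 2, but not the same: there the carbon was bound to an oxygen next to a carbonyl group, whereas here it is bound to an oxygen on an aromatic ring and a saturated chain carbon. Since compound 3 already gives only a limit, > 25000 nM, and the earlier step of a 17-fold higher number from compound 1 to compound 2 (1.22 log units; beyond the scatter) went toward a weaker inhibitor, compound 4 is expected to remain at or beyond that limit, with an expected step that the limit leaves unreadable from compound 3 to compound 4. The estimate for compound 4 is 60000 nM, between 20000 nM and 250000 nM.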

Compound 4, half-maximal inhibitory concentration: > 25000 nM
Compound 4: no number, only a limit; the forecaster's own chance of this, stated with the estimate: 90%; the middle value does not contradict the limit.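

In this assay compound 4 gives > 25000 nM, which is a limit of the assay and not a number. Compound 3 stands at the same limit, so the step from ethoxy to isopropoxy cannot be read: the limit of > 25000 nM in this assay, at which 2 of the 4 values shown sit. Among these compounds, the same kind of change gave a 17-fold higher number from compound 1 to compound 2 (1.22 log units; beyond the scatter) on the core of compound 1, but the series neither confirms nor rules out that methyl in place of hydrogen carries over to the second core, and the one readable new step, an at least 16-fold higher number from compound 2 to compound 4 (1.22 log units; beyond the scatter), belongs to a different change, isopropoxy in place of diethylamino.

The compounds shown leave open how far ethoxy and isopropoxy each lie past the limit, and so whether the two differ at all. They also leave open whether a methyl ester on the ethoxy core, or a cyclic amine such as morpholine or a longer chain on the oxygen, would give a readable number in this assay.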